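A few compounds are considered here, and "the series" means these few. Any claim that something is new, unique, unknown or untested is made for them only; others in the source may bear on it.

Compound 2 `Cc1ccc2c(c1)/C(=N/N1CC(=O)N(CCCN3CCN(C)CC3)C1=O)CCO2` gives 304 nM in an assay on cells (Ventricular myocyte) for inhibition of potassium voltage-gated channel subfamily KQT member 1 (Cavia porcellus), read by patch clamp (a lower number here means a stronger inhibitor, a higher number a weaker inhibitor), the higher of the two numbers measured, while compound 1 `COc1ccc2c(c1)/C(=N/N1CC(=O)N(CCCN3CCN(C)CC3)C1=O)CCO2` gives 1.9 nM. For the measured compounds named here, the one step measured between them, a 160-fold higher number from compound 1 to compound 2 (2.20 log units; beyond the scatter), shows that a change at this position of the core moves the number a long way. Compound 3 `CN1CCN(CCCN2C(=O)CN(/N=C3\CCOc4ccc(Cl)cc43)C2=O)CC1` differs from compound 2 by chloro in place of methyl on an aromatic carbon. Going by the values given here, no measured step contains a chloro group, so the only guidance is that the step from compound 1 to compound 2 was large, which shows the read-out is sensitive to what sits at this carbon. The direction for chloro is open; the estimate for compound 3 is therefore set close to compound 2, leaning slightly toward a lower number, as a 2.0-fold lower number from compound 2 to compound 3 (0.31 log units; beyond the scatter). Compound 3 is expected to give about 150 nM in this assay, within a wide range from 20 nM to 1000 nM.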

Compound 3, half-maximal inhibitory concentration: 5.8 nM
For compound 3 the middle estimate is 26-fold (1.41 log units) above the measured one; measured number outside the range, below it.
By their numbers in this assay, from the lowest: compound 1; then compound 3; then compound 2.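

In this assay, replacing methyl with chloro on this aromatic carbon gives a 52-fold lower number from compound 2 to compound 3 (1.72 log units; beyond the scatter), so the weak number of compound 2 does not follow from losing methoxy alone. Chloro does not fully match methoxy, with a 3.1-fold higher number from compound 1 to compound 3 (0.48 log units; beyond the scatter) as a modest step, yet chloro and methyl are alike in the computed count, each with one heavy atom, no hydrogen-bond donors or acceptors and no net charge. No measurement shown here accounts for the large gap between chloro and methyl. As far as these compounds go, it remains open whether fluoro, bromo, a nitrile or an ethoxy group at this carbon would give a number near that of chloro or methoxy, or near that of methyl. Also open, from the compounds shown here alone, is whether the same order would hold with a change elsewhere on the shared core.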